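Swapping a Methoxy for a Chloro on the Central Ring

This account rests on a few compounds, and the source may have more. Where it says the series, first, only, none or still open, it means among the compounds named here.

Two compounds share one core and are distinguished by a single substituent on the central ring. Compound 1 `NC(=O)c1cc(NS(=O)(=O)c2ccc(F)cc2)cc(-c2ccc3nc(NC(=O)C4CC4)sc3c2)c1` has in a functional assay on A549 cells (Homo sapiens) for antiproliferative activity, read by MTT assay, with a stated time of 72 h (on this read-out lower numbers stand for stronger inhibition and higher numbers for weaker inhibition), only the entry "not determined" (no result reported), so its potency is not known. Among the measured compounds shown here, compound 2 `COc1c(NS(=O)(=O)c2ccc(F)cc2)cc(-c2ccc3nc(NC(=O)C4CC4)sc3c2)cc1C(N)=O` is the only member with a number: in this assay compound 2 gives 6340 nM, a weak effect, and since no second number exists there is nothing to rank it against.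

Compound 3 `NC(=O)c1cc(-c2ccc3nc(NC(=O)C4CC4)sc3c2)cc(NS(=O)(=O)c2ccc(F)cc2)c1Cl` is the next step from compound 2. The change is chloro in place of methoxy on an aromatic carbon. For the measured compounds named here, no pair of measured compounds shows what such a swap does on this core, so there is no step to lean on.

Going by the values given here, with only one measured value, the expectation for compound 3 rests on the modest size of the substituent change and on compound 2 at 6340 nM. Compound 3 is expected to give about 5000 nM in this assay, between 1500 nM and 15000 nM. The expected step from compound 2 to compound 3, a 1.3-fold lower number from compound 2 to compound 3 (0.10 log units; within the scatter), lies within the usual scatter, with no clear direction.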

Compound 3, half-maximal inhibitory concentration: > 50000 nM
Compound 3 gave a limit, no number (the forecaster's own chance of this, stated with the estimate: 10%); middle value at least 10-fold (1.00 log units) from the limit.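

Compound 3 in this assay ends at a limit of the assay and not at a number: the limit of > 50000 nM in this assay, at which 1 of the 3 values shown sits.

Even so, the swap of methoxy for chloro on this aromatic carbon, ortho to a ((4-fluorophenyl)sulfonyl)amino group and ortho to a carbamoyl group, gives an at least 7.8-fold higher number from compound 2 to compound 3 (0.89 log units; beyond the scatter), and since higher numbers stand for weaker inhibition, the change goes against activity, and by more than the usual scatter. Among the compounds shown here, until this result no pair on the shared core showed anything about this position; now one pair shows that exchanging a group of two heavy atoms for a single chlorine here can take a compound that was already weak to beyond the limit, so the carbon is not indifferent to what it carries.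

On these data alone, compound 1, with a plain hydrogen on this carbon, has no number, so the steps to it cannot be read, and it stays open whether methoxy helps activity or chloro harms it. Also open, as far as these compounds go, is where an amine, a hydroxyl group or a fluorine on this carbon would fall relative to compound 2 and compound 3.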